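The source may report more compounds than this note shows. Statements on the series, on what has been measured and on what is new or still open speak of the compounds shown alone.

Values in a functional assay on U-937 cells (Homo sapiens) for antiproliferative activity, read by MTT assay, with a stated time of 72 h (on this read-out lower numbers stand for stronger inhibition and higher numbers for weaker inhibition), are as follows:

- compound 1 `O=C(CCCCCCc1nc(-c2ccc(C(F)(F)F)cc2)no1)NO` gives 2870 nM
- compound 2 `O=C(CCCCCCc1nc(-c2cccc([N+](=O)[O-])c2)no1)NO` gives 1160 nM
- compound 3 `O=C(CCCCCCc1nc(-c2ccc(C(F)(F)F)cc2)no1)C(F)(F)F` gives 1960 nM

Compound 2 (1160 nM) lies within the scatter of compound 3 (1960 nM). It shows a lower number than compound 1 (2870 nM), and that gap lies beyond the scatter.

The next compound, not yet measured, is compound 4 `O=C(CCCCCCc1nc(-c2cccc([N+](=O)[O-])c2)no1)C(F)(F)F`. It differs from compound 2 by trifluoromethyl in place of hydroxyamino on a carbonyl carbon. Among the measured compounds shown here, only one measured step makes this same exchange, and it is a 1.5-fold lower number from compound 1 to compound 3 (0.17 log units; within the scatter) in the same read-out. That single step lies within the scatter, so no change beyond the scatter is expected in this assay for the new pair, with at most a slight lean towards a lower number. The expected step is a 1.3-fold lower number from compound 2 to compound 4 (0.11 log units; within the scatter) and this estimate stays within the scatter. The estimated value for compound 4 is 900 nM (expected range 400 nM to 2100 nM).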

Compound 4, half-maximal inhibitory concentration: 560 nM
Compound 4: the middle estimate sits 1.6-fold (0.21 log units) above what was measured; the measured number falls inside the stated range.
By their numbers in this assay, from the lowest: compound 4; then compounds 2, 3 and 1 (each within the scatter of the next, the first and the last beyond it).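

In this assay, trifluoromethyl in place of hydroxyamino on a carbonyl carbon now gives a step beyond the scatter: a 2.1-fold lower number from compound 2 to compound 4 (0.32 log units; beyond the scatter). Among the compounds shown here, the earlier pair showed no change beyond the scatter, so this is the first sign that the exchange can lower the number, and it does so modestly. Hydroxyamino is therefore not needed at this position to keep the activity seen in this series, and the exchange points the same way on both cores, with the two steps not separable in size: the same change on two cores in this assay, a 1.5-fold lower number (0.17 log units; within the scatter) from compound 1 to compound 3 and a 2.1-fold lower number (0.32 log units; beyond the scatter) from compound 2 to compound 4, 1.4-fold (0.15 log units) apart, within the scatter of two such steps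

Still open, as far as these compounds go, is how other groups on this carbonyl carbon would compare, such as a methyl, an amine or the hydroxyl of a carboxylic acid. Also open, from the compounds shown here alone, is whether the same step holds with a longer chain or on further cores.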